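The compounds below may be only part of what the source reports. "The series", "measured", "known", "first", "only" and "open" are said of these compounds alone.

Measured so far in an ADME assay on BEAS-2B cells (Homo sapiens) for cytotoxicity, read by MTT assay, with a stated time of 72 h; on this read-out higher numbers stand for weaker inhibition of growth and lower numbers for stronger inhibition of growth:
compound 1, `CCCCCCOC(=O)Nc1ccc([Se][Se]c2ccc(NC(=O)OCCCCCC)cc2)cc1`: 6900 nM
compound 2, `C=CCOC(=O)Nc1ccc([Se]C#N)cc1`: 47400 nM
compound 3, `N#C[Se]c1ccc(NC(=O)Oc2ccccc2)cc1`: 38200 nM

Compound 2 stands highest of the three numbers shown. Its nearest neighbour is compound 3 with 38200 nM, a gap within the scatter; the widest gap separates it from compound 1 with 6900 nM, a gap beyond the scatter. The step under consideration leads to compound 4, `N#C[Se]c1ccc(NC(=O)OCc2ccccc2)cc1`, not yet measured in this assay. The change from compound 2 is phenyl in place of vinyl on a saturated chain carbon bound to an oxygen next to a carbonyl group. Within the data shown here, one measured step bears on it, the exchange a 1.2-fold lower number from compound 2 to compound 3 (0.09 log units; within the scatter), which put a ring on the oxygen next to the carbonyl group in place of a short unsaturated chain and left the number within the scatter. The present change likewise exchanges a short unsaturated chain for a ring, here on the saturated chain carbon bound to that oxygen. No movement beyond the scatter is therefore expected: the step of a 1.2-fold lower number from compound 2 to compound 4 (0.07 log units; within the scatter) is expected to stay within it. Compound 4 is thus estimated at 40000 nM, with a range from 15000 nM to 100000 nM.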

Compound 4, concentration for total growth inhibition: 34400 nM
Compound 4: middle estimate off by 1.2-fold (0.07 log units), on the high side; low and high end bracket the measured number.
By their numbers in this assay, from the lowest: compound 1; then compounds 4, 3 and 2 (each within the scatter of the next).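

In this assay the step of a 1.4-fold lower number from compound 2 to compound 4 (0.14 log units; within the scatter) stays within the scatter, so on the saturated chain carbon bound to an oxygen next to a carbonyl group, a six-membered aromatic ring of carbon only reads no differently from vinyl. Compound 3 at 38200 nM and compound 4 at 34400 nM also lie within the scatter of each other, so the number does not separate a ring carried through that chain carbon from one on the oxygen itself. No measurement at hand offers a reason for this flat response.

Compound 1 at 6900 nM differs from compound 2 in more than one place, so it does not show which of its changes goes with the lower number. Also open, as far as these compounds go, is whether an amine or a carboxylic acid in place of phenyl on that chain carbon would move the number beyond the scatter.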